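Shifting Two Chlorine Atoms on the Aryl Group

The source may hold more compounds than are shown below. What is called first, only, known or untested is meant among the compounds shown, and "the series" means these compounds.

Compound 1: `CC1(c2ccccc2)CC(=O)N(CC(=O)N2CCN(c3cccc(C(F)(F)F)c3)CC2)C1=O` — "not active" (no number reported)
Compound 2: `CC1(c2ccccc2)CC(=O)N(CC(=O)N2CCN(c3ccccc3)CC2)C1=O` — 100 mg/kg
Compound 3: `CC1(c2ccccc2)CC(=O)N(CC(=O)N2CCN(c3cccc(Cl)c3Cl)CC2)C1=O` — 300 mg/kg

The three measured compounds share one core and differ only in the aromatic group attached to an amine nitrogen in a ring. In a functional assay on the whole organism (strain CD-1) with Mus musculus as the target, with a stated time of 0.5 h (a higher number here means that more compound is needed for the effect, a lower number that less compound is needed), compound 2 gives 100 mg/kg, and compound 3 gives 300 mg/kg. Compound 1 is reported as "not active" (no number reported), so no number exists for it. Among the two numbers that were reported, compound 3 stands highest: the step of a 3.0-fold higher number from compound 2 to compound 3 (0.48 log units; beyond the scatter) lies beyond the scatter and shows that more of compound 3 is needed than of compound 2.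

Compound 4, `CC1(c2ccccc2)CC(=O)N(CC(=O)N2CCN(c3ccc(Cl)c(Cl)c3)CC2)C1=O`, keeps the same atoms as compound 3 but arranges them differently: 3,4-dichlorophenyl in place of 2,3-dichlorophenyl on an amine nitrogen in a ring. Going by the values given here, no measured step moves chlorine atoms around the ring, so the only step that bears on this change is a 3.0-fold higher number from compound 2 to compound 3 (0.48 log units; beyond the scatter), which tells how a dichlorophenyl group compares with plain phenyl but not how two dichlorophenyl patterns compare with each other. Compound 1 adds a caution that some aromatic groups give no activity at all. Compound 4 is therefore expected to land near compound 3, with a wide range, so that the step of no change at the digits printed from compound 3 to compound 4 (within the scatter) is expected to stay within the scatter. The estimate for compound 4 is 300 mg/kg, between 100 mg/kg and 1000 mg/kg.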

Compound 4, minimum effective dose: "not active" (no number reported)
No number was reported for compound 4, so the estimate cannot be set against anything.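

In this assay, going by these compounds alone, compound 4 gives "not active" (no number reported), so no step from compound 3 to compound 4 can be read. No available evidence explains this result. The compounds shown leave open whether any dose of compound 4 would produce the effect, and how the 3,4-dichlorophenyl and 2,3-dichlorophenyl groups would compare on a shared numerical scale.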